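Acyl substituents on the amine nitrogen and cytotoxicity

A few compounds are considered here, and "the series" means these few. Any claim that something is new, unique, unknown or untested is made for them only; others in the source may bear on it.

Measured compounds:
compound 1 `CCNC(=O)NC1=CS(=O)(=O)O[C@@]12[C@@H](CO[Si](C)(C)C(C)(C)C)O[C@@H](n1cc(C)c(=O)n(C)c1=O)[C@@H]2O[Si](C)(C)C(C)(C)C` — 4260 nM
compound 2 `Cc1cn([C@@H]2O[C@H](CO[Si](C)(C)C(C)(C)C)[C@@]3(OS(=O)(=O)C=C3NC(N)=O)[C@H]2O[Si](C)(C)C(C)(C)C)c(=O)n(C)c1=O` — 4360 nM
compound 3 `Cc1cn([C@@H]2O[C@H](CO[Si](C)(C)C(C)(C)C)[C@@]3(OS(=O)(=O)C=C3NCC(=O)C(N)=O)[C@H]2O[Si](C)(C)C(C)(C)C)c(=O)n(C)c1=O` — 9960 nM

In a functional assay on CCRF-CEM cells (Homo sapiens) (on this read-out higher numbers stand for lower toxicity in this test and lower numbers for higher toxicity in this test), compound 3 gives the highest of the three numbers. Its neighbours are compound 1 with 4260 nM and compound 2 with 4360 nM, both of which lie apart from compound 3 by steps marked as beyond the scatter: a 2.3-fold higher number from compound 1 to compound 3 (0.37 log units; beyond the scatter) and a 2.3-fold higher number from compound 2 to compound 3 (0.36 log units; beyond the scatter). Compound 1 and compound 2 themselves sit within the scatter of each other, since a 1.0-fold higher number from compound 1 to compound 2 (0.01 log units; within the scatter).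

Compound 4 `Cc1cn([C@@H]2O[C@H](CO[Si](C)(C)C(C)(C)C)[C@@]3(OS(=O)(=O)C=C3NC(=O)NC(=O)c3ccccc3)[C@H]2O[Si](C)(C)C(C)(C)C)c(=O)n(C)c1=O` has not yet been measured. Its difference from compound 3 is benzoylcarbamoyl in place of (carbamoylcarbonyl)methyl on an amine nitrogen.

The measured steps that bear on this change are the two that lead into compound 3: both were modest rises when the chain on the amine nitrogen was exchanged. Compound 4 carries a benzoylcarbamoyl group, which is closer in kind to the carbamoyl of compound 2 and the ethylcarbamoyl of compound 1 than to the chain of compound 3. The expected step is therefore a modest fall, a 1.7-fold lower number from compound 3 to compound 4 (0.22 log units; within the scatter), back toward the numbers of compound 1 and compound 2. For compound 4 the estimate in this assay is 6000 nM, with a range from 2500 nM to 15000 nM.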

Compound 4, half-maximal cytotoxic concentration: 2290 nM
For compound 4 the middle estimate is 2.6-fold (0.42 log units) above the measured one; measured number outside the range, below it.
By their numbers in this assay, from the lowest: compounds 4, 1 and 2 (each within the scatter of the next); then compound 3.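

In this assay, exchanging the (carbamoylcarbonyl)methyl on the amine nitrogen for benzoylcarbamoyl, which brings in a six-membered aromatic ring and more heavy atoms, gives the largest step in the series (a 4.3-fold lower number from compound 3 to compound 4 (0.64 log units; beyond the scatter)). Benzoyl on the amide-type nitrogen, however, does not separate compound 4 from the compounds carrying hydrogen or ethyl there (a 1.9-fold lower number from compound 2 to compound 4 (0.28 log units; within the scatter); a 1.9-fold lower number from compound 1 to compound 4 (0.27 log units; within the scatter)), so the aromatic ring adds no change beyond the scatter, and of the four compounds only compound 3 stands apart. Nothing in the available data explains why the (carbamoylcarbonyl)methyl compound gives the highest number.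

The compounds shown do not tell whether the benzoyl ring itself matters at the amide-type nitrogen, a question that an acetyl group or a longer alkyl chain at that place could address. They also leave open whether the higher number of compound 3 belongs to this particular chain or would persist with a chain ending in a carboxylic acid or an amine on the same amine nitrogen.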